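Benzyl in place of 3-chlorophenyl on an amide-type nitrogen

A few compounds are considered here, and "the series" means these few. Any claim that something is new, unique, unknown or untested is made for them only; others in the source may bear on it.

In a functional assay on HepG2 cells (Homo sapiens) for inhibition, read by MTT assay, with a stated time of 72 h (on this read-out lower numbers stand for stronger inhibition and higher numbers for weaker inhibition), compound 1 `O=C(Nc1cccc(F)c1)C1CCN(C/C=C/c2ccccc2)CC1` gives 51100 nM and compound 2 `O=C(Nc1cccc(Cl)c1)C1CCN(C/C=C/c2ccccc2)CC1` gives 20000 nM. Among the measured compounds shown here, compound 2 thus holds the lower of the only two numbers available. For the measured compounds named here, the single measured step, a 2.6-fold lower number from compound 1 to compound 2 (0.41 log units; beyond the scatter), places chloro in place of fluoro on an aromatic carbon, and it is modest but beyond the scatter.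

Compound 3 `O=C(NCc1ccccc1)C1CCN(C/C=C/c2ccccc2)CC1` has not yet been measured in this assay. It carries benzyl in place of 3-chlorophenyl on an amide-type nitrogen. Going by the values given here, no measured step covers this change directly. The halogen swap bears on it only loosely, as a sign that a single change on this aromatic group can shift the number by a modest amount, as seen in a 2.6-fold lower number from compound 1 to compound 2 (0.41 log units; beyond the scatter). Compound 3 loses the chloro group found in compound 2, so a move back toward the higher number of compound 1 seems the likelier direction. The expected change is a 2.0-fold higher number from compound 2 to compound 3 (0.30 log units; within the scatter), and its size is uncertain. For compound 3 the estimated value is 40000 nM, with an expected range of 14000 nM to 100000 nM.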

Compound 3, half-maximal inhibitory concentration: > 100000 nM
Compound 3: no number, only a limit; the forecaster's own chance of this, stated with the estimate: 15%; middle value at least 2.5-fold (0.39 log units) from the limit.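

The earlier compounds shown here varied only the halogen on a phenyl group attached directly to the amide-type nitrogen, and they left open how far the number depends on that aryl group itself. In this assay, replacing 3-chlorophenyl with benzyl keeps the count of heavy atoms and the single aromatic ring, yet it gives an at least 5.0-fold higher number from compound 2 to compound 3 (0.69 log units; beyond the scatter), so this position tolerates poorly a change that leaves those counts intact. The matching change from the fluoro compound gives an at least 1.9-fold higher number from compound 1 to compound 3 (0.29 log units; that floor lies within the scatter), so that pair alone does not establish a loss, and compound 3 gives a limit of the assay rather than a number, which makes both steps floors: the limit of > 100000 nM in this assay, at which 1 of the 3 values shown sits.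

Still open, as far as these compounds go, is whether the step is carried by the loss of chlorine or by the change from a phenyl to a benzyl group, since compound 3 differs from compound 2 in both; a 3-chlorobenzyl group or an unsubstituted phenyl on the same nitrogen would separate the two. Also open, from the compounds shown here alone, is how a bromo or a methoxy group in place of the chloro would read on the 3-chlorophenyl series.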